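Carboxy to 3-carboxypropyl on a thiazole-bearing aniline

The compounds below may be only part of what the source reports. "The series", "measured", "known", "first", "only" and "open" are said of these compounds alone.

Measured in a functional assay on CHO cells for agonist activity at Free fatty acid receptor 1 (Homo sapiens); a higher number here means that more compound is needed for the effect, a lower number that less compound is needed:
Compound 1, `O=C(O)c1ccc(NCc2cccc(Oc3ccccc3)c2)cc1`, gives < 10000 nM, a limit of the assay.
Compound 2, `Cc1nc(-c2ccc(C(F)(F)F)cc2)sc1CNc1ccc(C(=O)O)cc1`, gives < 10000 nM, a limit of the assay.
Compound 3, `O=C(O)CCCc1ccc(NCc2cccc(Oc3ccccc3)c2)cc1`, gives 1120 nM.

Compound 2 thus stands at a limit, not a number, and so does compound 1; only compound 3 gives a value in this assay. Compound 4, `Cc1nc(-c2ccc(C(F)(F)F)cc2)sc1CNc1ccc(CCCC(=O)O)cc1`, differs from compound 2 by 3-carboxypropyl in place of carboxy on an aromatic carbon. Among the measured compounds shown here, the one measured step that bears on this change, a step that the limit leaves unreadable from compound 1 to compound 3, is the same change on the core of compound 1, but its size is not readable (the limit of < 10000 nM in this assay, at which 2 of the 3 values shown sit). Compound 3 nonetheless carries the chain and gives a number, so compound 4 is expected to give a number too, the step that the limit leaves unreadable from compound 2 to compound 4 being an estimate only. For compound 4 the expected value is 500 nM, between 80 nM and 3000 nM.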

Compound 4, half-maximal effective concentration: < 10000 nM
Compound 4: a limit, no number; the forecaster's own chance of this, stated with the estimate: 8%; the middle value is on the limit's open side.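

Among the compounds shown here, compound 2 and compound 4 both stand at a limit of the assay, not a number, so no step between them can be read. The compounds shown leave open how large the change from carboxy to 3-carboxypropyl is on either core.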